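The source may hold more compounds than are shown below. What is called first, only, known or untested is meant among the compounds shown, and "the series" means these compounds.

Measured so far in a functional assay on DU-145 cells (Homo sapiens) for inhibition, read by trypan blue exclusion, with a stated time of 72 h; a higher number here means a weaker inhibitor, a lower number a stronger inhibitor:
- compound 1 `Cn1c(=O)c(S(=O)(=O)c2ccc(F)cc2[N+](=O)[O-])cc2cnc(Nc3ccc4[nH]ccc4c3)nc21`: 1500 nM
- compound 2 `Cn1c(=O)c(S(=O)(=O)c2ccc(F)cc2F)cc2cnc(Nc3ccc4cccc(O)c4n3)nc21`: 5000 nM
- compound 3 `Cn1c(=O)c(S(=O)(=O)c2ccccc2)cc2cnc(Nc3ccc4ncccc4c3)nc21`: 50000 nM

Compound 1 gives the lowest number of the three and is therefore the strongest inhibitor in this assay; compound 2 stands nearest, at a higher number that lies beyond the scatter, and compound 3 stands furthest, also beyond the scatter. The three compounds differ from one another in more than one place, so no single change can be isolated among them; what the numbers show is only that the substituted phenyl on the sulfonyl sulfur of compound 1 goes with a lower number than the unsubstituted phenyl of compound 3, with the other parts of the molecules differing too.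

Compound 4 `Cn1c(=O)c(S(=O)(=O)c2ccc(N)cc2F)cc2cnc(Nc3ccc4[nH]ccc4c3)nc21` is not yet measured. It differs from compound 1 in one place: 4-amino-2-fluorophenyl in place of 4-fluoro-2-nitrophenyl on a sulfonyl sulfur. The aniline part and the shared core are unchanged.

Among the compounds with values here, no measured pair shows this change. Within the data shown here, with no step to lean on, a modest move is expected in this assay, more likely toward a higher number than a lower one, and possibly within the scatter. The estimated step from compound 1 to compound 4 is a 2.0-fold higher number from compound 1 to compound 4 (0.30 log units; within the scatter). For compound 4 the expected value in this assay is 3000 nM, with a range from 800 nM to 12000 nM.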

Compound 4, half-maximal inhibitory concentration: 8000 nM
Estimate against measurement, compound 4: 2.7-fold (0.43 log units) below; measured number inside the range.
By their numbers in this assay, from the lowest: compound 1; then compounds 2 and 4 (each within the scatter of the next); then compound 3.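

In this assay, the aryl group on the sulfonyl sulfur now has its first single-place comparison: 4-amino-2-fluorophenyl in place of 4-fluoro-2-nitrophenyl gives a 5.3-fold higher number from compound 1 to compound 4 (0.73 log units; beyond the scatter), with the aniline part and the shared core unchanged. Within the data shown here, this position is therefore not indifferent to the group it carries, since this exchange alone moves the number beyond the scatter, something the earlier compounds, which differ in more than one place, could not show. Nothing in the data at hand explains the step.

The exchange replaces the whole aryl group, so the compounds shown do not separate what the nitro, amino and fluoro substituents each contribute to the step. Also open, as far as these compounds go, is how this position responds, with the aniline part and the shared core held constant, to other groups on the phenyl ring, such as a methoxy group or a carboxylic acid.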